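Furan for thiophene on a hydrazinyl pyrimidinone core

A few compounds are considered here, and "the series" means these few. Any claim that something is new, unique, unknown or untested is made for them only; others in the source may bear on it.

Compound 1 `CCOC(=O)c1cnn(-c2nc(-c3ccco3)c(C#N)c(=O)n2C)c1N`: 104 ug/mL
Compound 2 `Cn1c(NN)nc(-c2cccs2)c(C#N)c1=O`: 53 ug/mL
Compound 3 `CCOC(=O)c1cnn(-c2nc(-c3cccs3)c(C#N)c(=O)n2C)c1N`: 109 ug/mL

Of the compounds shown here, three have been measured in a functional assay, with a stated time of 10 min; a lower number here means a stronger inhibitor, a higher number a weaker inhibitor. Compound 1 and compound 3 share one core; compound 2 carries a different core, and the difference between the two cores is not broken down here. In this assay compound 2 gives 53 ug/mL, the lowest of the three numbers, though compound 1 with 104 ug/mL lies within the scatter of it; only compound 3 with 109 ug/mL stands beyond it.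

One change has been made among the measured pairs: furan-2-yl in place of thiophen-2-yl on an aromatic carbon. It gave a 1.0-fold lower number from compound 3 to compound 1 (0.02 log units; within the scatter).

Compound 4 `Cn1c(NN)nc(-c2ccco2)c(C#N)c1=O` has not yet been measured in this assay. It comes from compound 2 by the same kind of change: furan-2-yl in place of thiophen-2-yl on an aromatic carbon. The surroundings are not identical word for word: in compound 2 the carbon is meta to an aminoamino group (2 heavy atoms), whereas in compound 3 it is meta to a large group. Because the earlier step of a 1.0-fold lower number from compound 3 to compound 1 (0.02 log units; within the scatter) was flat, compound 4 is expected to sit close to compound 2, an estimated 1.0-fold lower number from compound 2 to compound 4 (0.01 log units; within the scatter). The estimate for compound 4 is therefore 52 ug/mL, expected to fall between 28 ug/mL and 95 ug/mL.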

Compound 4, half-maximal inhibitory concentration: 58 ug/mL
Compound 4: the middle estimate sits 1.1-fold (0.05 log units) below what was measured; the measured number falls inside the stated range.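

In this assay, furan-2-yl in place of thiophen-2-yl on the second core gave a 1.1-fold higher number from compound 2 to compound 4 (0.04 log units; within the scatter), so the exchange again made no difference that stands out from the scatter. Set beside the earlier step on the other core, the two readings agree: the same change on two cores in this assay, a 1.0-fold lower number (0.02 log units; within the scatter) from compound 3 to compound 1 and a 1.1-fold higher number (0.04 log units; within the scatter) from compound 2 to compound 4, 1.1-fold (0.06 log units) apart, within the scatter of two such steps. This shows that, across these two pairs, the exchange of one five-membered aromatic ring for the other carried from one core to the other without a visible shift, but it rests on two flat steps only, and it shows neither that the same would hold on a further core nor that either ring contributes anything to the numbers, as neither ring was compared with a compound lacking it.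

The compounds shown leave open how this position would read with a group other than these two rings, such as a phenyl ring, a pyridine or a saturated amine like morpholine. Also open, as far as these compounds go, is how the series would respond at the other positions, for instance with a carboxylic acid in place of the cyano group or a longer chain in place of the methyl group.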